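One Aryl Swap Seen Twice on a Shared Core

The source may report more compounds than this note shows. Statements on the series, on what has been measured and on what is new or still open speak of the compounds shown alone.

Three compounds built on a shared core were tested in a functional assay on U-87MG ATCC cells for antiproliferative activity against U-87 MG (Homo sapiens), read by MTT assay, with a stated time of 48 h, tested at 10 uM; a lower number here means a stronger effect, a higher number a weaker effect of the compound at the concentration tested. Compound 1 `COc1cccc(-c2nc(SCC(=O)c3sc(-c4ccccc4)nc3C)[nH]c(=O)c2C#N)c1` gives 90.2%, compound 2 `Cc1nc(-c2ccccc2)sc1C(=O)CSc1nc(-c2ccc(Cl)cc2)c(C#N)c(=O)[nH]1` gives 85.2%, and compound 3 `Cc1nc(-c2ccc(Cl)cc2)sc1C(=O)CSc1nc(-c2ccc(Cl)cc2)c(C#N)c(=O)[nH]1` gives 98.4%. The cores of compound 2 and compound 3 differ by chloro in place of hydrogen on an aromatic carbon, which made a step of a number 13.2 percentage points higher from compound 2 to compound 3 (beyond the scatter). Compound 4 `COc1cccc(-c2nc(SCC(=O)c3sc(-c4ccc(Cl)cc4)nc3C)[nH]c(=O)c2C#N)c1` has not yet been measured; compound 4 differs from compound 3 by 3-methoxyphenyl in place of 4-chlorophenyl on an aromatic carbon. The same change, (3-methoxyphenyl in place of 4-chlorophenyl on an aromatic carbon), was already made from compound 2 to compound 1 and gave a number 5 percentage points higher from compound 2 to compound 1 (within the scatter). Because the earlier step of a number 5 percentage points higher from compound 2 to compound 1 (within the scatter) lay within the scatter, the step from compound 3 to compound 4 is expected to be small as well, a number 0.6 percentage points higher from compound 3 to compound 4 (within the scatter). Compound 4 is thus estimated at 99% in this assay, with a likely range from 88% to 108%.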

Compound 4, a percentage reported as activity, at one concentration (the size of the read-out at that concentration, not a potency): 89.7%
Compound 4: middle estimate off by 9.3 percentage points, on the high side, within the range that was stated.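

Putting 3-methoxyphenyl in place of 4-chlorophenyl gives a number 8.7 percentage points lower from compound 3 to compound 4 (within the scatter) in this assay, and this step does not differ measurably from the one seen for the same change on the other core: the same change on two cores in this assay, a number 5 percentage points higher (within the scatter) from compound 2 to compound 1 and a number 8.7 percentage points lower (within the scatter) from compound 3 to compound 4, 13.7 percentage points apart, within the scatter of two such steps. Adding the chloro group to the phenyl ring gives a number 0.5 percentage points lower from compound 1 to compound 4 (within the scatter), and its two steps likewise cannot be told apart: the same change on two cores in this assay, a number 13.2 percentage points higher (beyond the scatter) from compound 2 to compound 3 and a number 0.5 percentage points lower (within the scatter) from compound 1 to compound 4, 13.7 percentage points apart, within the scatter of two such steps. Among the compounds shown here, this shows that nothing here separates the two cores, but with only two pairs it does not show that either change carries over reliably, since a real difference of modest size could stay hidden in the scatter.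

The compounds shown leave open whether a different group at the same place, such as an amine or a carboxylic acid, would lower the number. They also leave open how either change behaves on any other core.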